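Removing a methoxy from the dimethoxy aryl hydrazone

This account rests on a few compounds, and the source may have more. Where it says the series, first, only, none or still open, it means among the compounds named here.

Measured compounds and values in an ADME assay on WI-38 cells (Homo sapiens) for cytotoxicity, read by colorimetric assay and crystal violet staining, with a stated time of 24 h; on this read-out higher numbers stand for weaker inhibition and lower numbers for stronger inhibition:
compound 1 `COc1ccc(OC)c(/C=N/NC(=O)c2ccc(-c3cccc(Cl)c3)nc2C)c1`: 188 ug/mL
compound 2 `COc1ccc(/C=N/NC(=O)c2ccc(-c3ccc(Cl)cc3)nc2C)cc1OC`: 443 ug/mL
compound 3 `COc1cc(/C=N/NC(=O)c2ccc(-c3ccc(Cl)cc3)nc2C)cc(OC)c1OC`: 41.1 ug/mL

Compound 2 gives the highest number of the three in this assay. Compound 1 gives a number lower than compound 2, and compound 3 gives the lowest number of the set.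

Compound 4 `COc1ccc(/C=N/NC(=O)c2ccc(-c3ccc(Cl)cc3)nc2C)cc1` has not yet been measured. It differs from compound 2 by a single change: hydrogen in place of methoxy on an aromatic carbon.

For the measured compounds named here, only one measured step bears on this kind of change, that from compound 2 to compound 3, where adding a methoxy gave an 11-fold lower number from compound 2 to compound 3 (1.03 log units; beyond the scatter). Going by the values given here, the change to compound 4 runs in the opposite direction, taking a methoxy away, though at a different position than the one compound 3 gained. On that basis the number for compound 4 is expected to stay at or move above that of compound 2, giving an estimated step of a 1.0-fold higher number from compound 2 to compound 4 (0.01 log units; within the scatter). Compound 4 is therefore estimated at 450 ug/mL in this assay, within a range from 200 ug/mL to 1000 ug/mL.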

Compound 4, half-maximal inhibitory concentration: 500 ug/mL
The estimate for compound 4 lay 1.1-fold (0.05 log units) below the measured number, and the stated range covers the measured number.
By their numbers in this assay, from the lowest: compound 3; then compound 1; then compounds 2 and 4 (each within the scatter of the next).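

In this assay, the methoxy ortho to a methoxy group and meta to a large group can give way to hydrogen without a change beyond the scatter, with a 1.1-fold higher number from compound 2 to compound 4 (0.05 log units; within the scatter) as the step. For the compounds shown here, the only earlier step on a methoxy was large, at an 11-fold lower number from compound 2 to compound 3 (1.03 log units; beyond the scatter), so a methoxy change does not move this number by a similar amount at every place on the ring. Nothing shown gives a reason for this difference between the two steps.

The compounds shown leave open whether a hydroxyl, an amine or a longer chain such as ethoxy at this place would also stay within the scatter of compound 2. They also leave open what taking away the remaining methoxy of compound 4 would do.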